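A few compounds are considered here, and "the series" means these few. Any claim that something is new, unique, unknown or untested is made for them only; others in the source may bear on it.

Compound 3, `COc1cc(OC)c(-c2coc3cc(OCc4ccccc4C)ccc3c2=O)cc1OC`, gives the lowest number among the three measured compounds in a functional assay on U-251 cells (Homo sapiens) for antiproliferative activity, read by MTT assay, with a stated time of 24 h (a lower number here means a stronger inhibitor, a higher number a weaker inhibitor), where compound 3 gives 2000 nM. Compound 1, `COc1cc(OC)c(-c2coc3cc(OCc4ccccc4)ccc3c2=O)cc1OC`, gives 6750 nM in this assay, and compound 2, `COc1cc(OC)c(-c2coc3cc(OCc4ccccc4F)ccc3c2=O)cc1OC`, gives 2890 nM. The step of a 3.4-fold lower number from compound 1 to compound 3 (0.53 log units; beyond the scatter) and the step of a 2.3-fold lower number from compound 1 to compound 2 (0.37 log units; beyond the scatter) both lie beyond the scatter, whereas the step of a 1.4-fold lower number from compound 2 to compound 3 (0.16 log units; within the scatter) lies within it, so compound 2 and compound 3 cannot be ordered against each other.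

Compound 4, `COc1cc(OC)c(-c2coc3cc(OCc4ccccc4Br)ccc3c2=O)cc1OC`, differs from compound 3 in one place: bromo in place of methyl on an aromatic carbon. The step that bears most directly on this change is a 1.4-fold lower number from compound 2 to compound 3 (0.16 log units; within the scatter), which shows that exchanging one small substituent for another on this aromatic carbon, ortho to a large group, left the number within the scatter. The larger steps of a 3.4-fold lower number from compound 1 to compound 3 (0.53 log units; beyond the scatter) and a 2.3-fold lower number from compound 1 to compound 2 (0.37 log units; beyond the scatter) only show that any substituent at this position gives a lower number than hydrogen. Compound 4 is therefore expected to stay close to compound 3, with an estimated step of a 1.1-fold lower number from compound 3 to compound 4 (0.05 log units; within the scatter) that does not clearly exceed the scatter. For compound 4 the estimate in this assay is 1800 nM, with a range from 800 nM to 4000 nM.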

Compound 4, half-maximal inhibitory concentration: > 10000 nM
Compound 4: only a limit was reported (the forecaster's own chance of this, stated with the estimate: 2%); middle value at least 5.5-fold (0.74 log units) from the limit.
By their numbers in this assay, from the lowest: compounds 3 and 2 (each within the scatter of the next); then compound 1. At a limit, above all of these: compound 4.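

In this assay compound 4 gave only a limit, not a number: the limit of > 10000 nM in this assay, at which 1 of the 4 values shown sits. At this aromatic carbon, ortho to a large group, the identity of the substituent does matter: bromo in place of methyl gives an at least 5.0-fold higher number from compound 3 to compound 4 (0.69 log units; beyond the scatter), and bromo in place of fluoro gives an at least 3.4-fold higher number from compound 2 to compound 4 (0.53 log units; beyond the scatter), whereas fluoro and methyl could not be ordered against each other. Bromo also does not share the clear gain over hydrogen seen with fluoro and methyl, since bromo in place of hydrogen gives an at least 1.4-fold higher number from compound 1 to compound 4 (0.17 log units; that floor lies within the scatter), so compound 4 is not firmly separated from compound 1.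

The compounds shown leave open how far compound 4 lies beyond its limit. They also leave open whether chloro or methoxy at this carbon would group with fluoro and methyl or with bromo.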